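This account rests on a few compounds, and the source may have more. Where it says the series, first, only, none or still open, it means among the compounds named here.

Compound 2, with the structure `Cc1ccc(C(=O)Nc2cc(-c3ccccc3)nn2-c2ccccc2)cc1C`, is the more potent of the two measured compounds in a functional assay on cells for positive allosteric modulation of metabotropic glutamate receptor 5 (Rattus norvegicus), read by calcium flux; a higher number here means that more compound is needed for the effect, a lower number that less compound is needed: compound 2 gives 20 nM, while compound 1, with the structure `O=C(Nc1cc(-c2ccccc2)nn1-c1ccccc1)c1cccc(C(F)(F)F)c1`, gives 228 nM. Among the measured compounds shown here, the one measured step, an 11-fold lower number from compound 1 to compound 2 (1.06 log units; beyond the scatter), swapped one group on the carbonyl carbon for another and moved the number a long way. Compound 3, with the structure `O=C(Nc1cc(-c2ccccc2)nn1-c1ccccc1)c1ccc(Cl)c(Cl)c1`, changes the same place again: 3,4-dichlorophenyl in place of 3,4-dimethylphenyl on a carbonyl carbon. For the measured compounds named here, no measured step involves 3,4-dichlorophenyl, so the only guide is that the group on the carbonyl carbon can shift this assay strongly, and that compound 2 already sits at the lowest number seen. A modest rise from compound 2 is expected, so the step to compound 3 is estimated as a 2.0-fold higher number from compound 2 to compound 3 (0.30 log units; within the scatter). Compound 3 is therefore expected to give about 40 nM in this assay, plausibly anywhere from 10 nM to 160 nM.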

Compound 3, half-maximal effective concentration: 13 nM
The estimate for compound 3 lay 3.1-fold (0.49 log units) above the measured number, within the range that was stated.
By their numbers in this assay, from the lowest: compounds 3 and 2 (each within the scatter of the next); then compound 1.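

In this assay, 3,4-dichlorophenyl in place of 3,4-dimethylphenyl on a carbonyl carbon gives a 1.5-fold lower number from compound 2 to compound 3 (0.19 log units; within the scatter) and so leaves the two groups indistinguishable at this position. The step of an 18-fold lower number from compound 1 to compound 3 (1.24 log units; beyond the scatter) is large, like an 11-fold lower number from compound 1 to compound 2 (1.06 log units; beyond the scatter) before it, so two different groups now stand well clear of 3-(trifluoromethyl)phenyl, and that large difference is not tied to 3,4-dimethylphenyl alone. Nothing measured here explains why these two groups read alike or why 3-(trifluoromethyl)phenyl reads differently.

As far as these compounds go, it remains open whether the ring on the carbonyl carbon needs two substituents at all, and whether plain phenyl, or a ring carrying an amine, a carboxylic acid or a longer alkyl chain, would keep the number close to those of compound 2 and compound 3. From the compounds shown here alone, how changes elsewhere on the shared core would read in this assay is also open.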